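The source may hold more compounds than are shown below. What is called first, only, known or untested is meant among the compounds shown, and "the series" means these compounds.

Compound 1: `COc1ccc2nc(C)cc(OC(C)(C)C(=O)Nc3cc(C)cc(C)c3)c2c1` — 6.37
Compound 2: `COc1ccc2nc(C)cc(OCC(=O)Nc3cccc(C)c3)c2c1` — 4.83

Of the compounds shown here, two have so far been measured in a physicochemical assay for lipophilicity, read by HPLC, in phosphate buffer, measured as chromatographic lipophilicity, at pH 7.4; a higher number here means a more lipophilic compound, a lower number a more polar compound. Compound 1 gives 6.37 and compound 2 gives 4.83 in this assay. Within the data shown here, compound 2 therefore holds the lower of the two numbers, and its only neighbour, compound 1, sits higher by a gap that is clearly beyond the usual scatter of this kind of measurement.

Compound 3, `COc1ccc2nc(C)cc(OCC(=O)Nc3cc(C)ccc3OC)c2c1`, has not yet been measured in this assay. It shares the core of compound 2 and differs from it in one place: methoxy in place of hydrogen on an aromatic carbon. In words, a methoxy group takes the place of a hydrogen on an aromatic carbon of the six-membered ring that carries the amide, ortho to a large group and para to a methyl group.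

Among the measured compounds shown here, no step between measured compounds shows what such a change does here, so the expectation rests on the change alone. A small upward step, a number 0.27 log units higher from compound 2 to compound 3 (within the scatter), is expected from compound 2 to compound 3, close to the edge of the scatter. Compound 3 is therefore estimated at 5.1, with a likely range from 4.7 to 5.6.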

Compound 3, distribution coefficient: 5.65
Compound 3: the middle estimate sits 0.55 log units below what was measured; measured number outside the range, above it.
By their numbers in this assay, from the lowest: compound 2; then compound 3; then compound 1.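

Among these compounds, with methoxy in place of hydrogen on an aromatic carbon, ortho to a large group and para to a methyl group, this assay records a number 0.82 log units higher from compound 2 to compound 3 (beyond the scatter) as the first step here that isolates a single change. The two earlier compounds differ in more than one place and could not show this, whereas the change from 3-methylphenyl to 2-methoxy-5-methylphenyl shows that this position responds clearly in the measurement when a group of 2 heavy atoms replaces a hydrogen. Nothing available explains why the number moves upward at this position.

A single step cannot show whether the same rise would appear with methoxy elsewhere on this ring, or with another group in the same place, such as hydroxyl, an amine, chlorine or the longer ethoxy. As far as these compounds go, compound 1 also differs from compound 3 in more than one place, so its higher number cannot be divided among its differences, and the part played by the two methyl groups on the carbon of its linking chain remains open.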